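The compounds below may be only part of what the source reports. "The series", "measured", "known", "first", "only" and "open" are said of these compounds alone.

Compound 1 `Nc1nc2c(nc(N)n2COCCO)c(=O)[nH]1` gives 200 ug/mL in a functional assay (Oryctolagus cuniculus) for inhibition; on this read-out lower numbers stand for stronger inhibition and higher numbers for weaker inhibition. Compound 2 `CNc1nc2c(=O)[nH]c(N)nc2n1COCCO` reaches only the limit of this assay, > 400 ug/mL. The step of an at least 2.0-fold higher number from compound 1 to compound 2 (0.30 log units; that floor lies within the scatter) is thus a floor, set by the limit of > 400 ug/mL in this assay, at which 1 of the 2 values shown sits. Compound 3 `CN(C)c1nc2c(=O)[nH]c(N)nc2n1COCCO` carries the same kind of change once more: methyl in place of hydrogen on a nitrogen on an aromatic ring. Within the data shown here, the only step that bears on it, an at least 2.0-fold higher number from compound 1 to compound 2 (0.30 log units; that floor lies within the scatter), has a floor within the scatter, so it fixes neither size nor direction; a limit rather than a number is expected again in this assay. For compound 3 the estimate is 800 ug/mL, range 300 ug/mL to 3000 ug/mL, an expected step that the limit leaves unreadable from compound 2 to compound 3.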

Compound 3, concentration for 50% inhibition: > 400 ug/mL
Compound 3 ended at the assay's limit; the forecaster's own chance of this, stated with the estimate: 85%; the middle value does not contradict the limit.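

The second methyl on this nitrogen brings no value back inside the range of this assay. Dimethylamino in place of amino on an aromatic carbon gives an at least 2.0-fold higher number from compound 1 to compound 3 (0.30 log units; that floor lies within the scatter), so neither size nor direction of this change is fixed. The step from methylamino to dimethylamino cannot be read: the limit of > 400 ug/mL in this assay, at which 2 of the 3 values shown sit.

On these data alone, how far the two methylated compounds lie past the limit remains open. Also open, as far as these compounds go, is whether a longer chain on this nitrogen, such as ethylamino, or an acetylamino group in place of amino would give a readable number.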